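Working notes: aryl hydrazone change from compound 1 to compound 4

The compounds below may be only part of what the source reports. "The series", "measured", "known", "first", "only" and "open" are said of these compounds alone.

Measured compounds in a functional assay on ECa-109 cells (Homo sapiens) for antiproliferative activity, read by MTT assay, with a stated time of 72 h; on this read-out lower numbers stand for stronger inhibition and higher numbers for weaker inhibition:
compound 1, `CCCSc1nc(N/N=C/c2ccc(C)cc2)c2nnn(Cc3ccccc3)c2n1`: > 64000 nM
compound 2, `CCCSc1nc(N/N=C(\C)c2ccccc2O)c2nnn(Cc3ccccc3Cl)c2n1`: > 64000 nM
compound 3, `CCCSc1nc(N/N=C/c2ccc(N(C)C)cc2)c2nnn(Cc3ccccc3)c2n1`: 20000 nM
compound 4, `CCCSc1nc(N/N=C(\C)c2ccc(Br)cc2)c2nnn(Cc3ccccc3)c2n1`: not yet measured

For compound 1 the value > 64000 nM is a limit of this assay, not a number. For compound 2 the value > 64000 nM is likewise a limit. Only compound 3 gives a number, 20000 nM in this assay. For the measured compounds named here, compound 1 therefore stands at the limit, with two of the three values at the limit of > 64000 nM in this assay, at which 2 of the 3 values shown sit, and the one measured step away from it is an at least 3.2-fold lower number from compound 1 to compound 3 (0.50 log units; beyond the scatter), where a dimethylamino replaces a methyl on an aromatic carbon.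

The change to compound 4 is different in kind: a group of 10 heavy atoms (8 carbon, 1 nitrogen, 1 bromine; one six-membered aromatic ring of carbon only) in place of a group of 9 heavy atoms (8 carbon, 1 nitrogen; one six-membered aromatic ring of carbon only), on a nitrogen on an aromatic ring. Going by the values given here, no measured step concerns this exchange; the step of an at least 3.2-fold lower number from compound 1 to compound 3 (0.50 log units; beyond the scatter) involves another group and so gives no direct guidance. Compound 2, which carries the same kind of group with a methyl on the double bond, also sits at a limit, though its benzyl part differs as well.

Nothing shown supports a move beyond the scatter. The expected step is an at least 1.0-fold lower number from compound 1 to compound 4 (0.02 log units; that floor lies within the scatter). Compound 4 is estimated at 60000 nM. The expected range for compound 4 runs from 20000 nM to 200000 nM, with a limit the most likely outcome.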

Compound 4, half-maximal inhibitory concentration: 4670 nM
Beside the measured number, compound 4's estimate is 13-fold (1.11 log units) above it; measured number outside the range, below it.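

In this assay, for the compounds shown here, the exchange on a nitrogen on an aromatic ring gives an at least 13-fold lower number from compound 1 to compound 4 (1.13 log units; beyond the scatter), the first evidence that this group itself, and not only the substituent changed in an at least 3.2-fold lower number from compound 1 to compound 3 (0.50 log units; beyond the scatter), can move the series beyond the scatter. The entering group differs from the leaving one in two ways, a bromine in place of the methyl on the aromatic ring and a new methyl on the double bond, and together these give compound 4 a measured number on the benzyl-bearing core of compound 1. Compound 1 gives > 64000 nM, which is a limit and not a number, so the step is a floor and its true size cannot be read: the limit of > 64000 nM in this assay, at which 2 of the 4 values shown sit.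

The compounds shown do not separate the contribution of the bromine from that of the methyl on the double bond, since compound 4 carries both and no compound shown differs from it in only one of them. As far as these compounds go, it also stays open whether a fluorine or a methoxy in place of the bromine, or a longer chain in place of the methyl on the double bond, would keep or lose this number.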